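The compounds below may be only part of what the source reports. "The series", "measured", "known", "first", "only" and "open" are said of these compounds alone.

In a functional assay on HOP-62 cells (Homo sapiens) for inhibition, read by sulforhodamine B assay, with a stated time of 48 h (a lower number here means a stronger inhibitor of growth, a higher number a weaker inhibitor of growth), compound 2 `COc1cc2cc(Oc3ccc(NC(=O)Nc4ccc(Cl)c(C(F)(F)F)c4)cc3)c(C)nc2cc1OC` gives 1300 nM, the lower of the two numbers shown so far, while compound 1 `COc1cc2cc(Oc3ccc(NC(=O)Nc4cccc(C(F)(F)F)c4)cc3)c(C)nc2cc1OC` gives 2330 nM; the gap between them stays within the scatter, so the two are not separated. Among the measured compounds shown here, the one step between measured compounds, a 1.8-fold lower number from compound 1 to compound 2 (0.25 log units; within the scatter), was small. Compound 3 `COc1cc2cc(Oc3ccc(NC(=O)Nc4ccc(Cl)c(Cl)c4)cc3)c(C)nc2cc1OC` has not yet been measured in this assay. It differs from compound 2 by chloro in place of trifluoromethyl on an aromatic carbon. For the measured compounds named here, no measured step exchanges a trifluoromethyl for a chloro, so the step from compound 1 to compound 2 bears on it only loosely, through the same ring, and that step did not go beyond the scatter. For compound 3 no step beyond the scatter is expected, with the estimated change being a 1.2-fold higher number from compound 2 to compound 3 (0.06 log units; within the scatter). The estimate for compound 3 in this assay is 1500 nM, within a range from 600 nM to 4000 nM.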

Compound 3, concentration for 50% growth inhibition: 3550 nM
For compound 3 the middle estimate is 2.4-fold (0.37 log units) below the measured one; the range from low to high includes it.
By their numbers in this assay, from the lowest: compounds 2, 1 and 3 (each within the scatter of the next, the first and the last beyond it).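

In this assay, among the compounds shown here, the exchange of trifluoromethyl for chloro, ortho to a chloro group, gives the first step that lies beyond the scatter: a 2.7-fold higher number from compound 2 to compound 3 (0.44 log units; beyond the scatter). This shows that the number responds to the group at this position, although the step is modest and rests on a single pair. The wider change gives a 1.5-fold higher number from compound 1 to compound 3 (0.18 log units; within the scatter), which stays within the scatter and leaves those two compounds unseparated, and nothing measured here accounts for either result.

The compounds shown leave open how an amine, a methoxy group or a nitrile would read at this position in place of trifluoromethyl. They also leave open whether the exchange of trifluoromethyl for chloro would give a similar step without the neighbouring chloro group.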